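A few compounds are considered here, and "the series" means these few. Any claim that something is new, unique, unknown or untested is made for them only; others in the source may bear on it.

Of the compounds shown here, two sharing one core have been measured so far. Compound 1 `CN(C)c1ccc(/C=C/C(=O)/C=C(O)/C=C/c2ccc(N(C)C)cc2)cc1` carries that core alone, while compound 2 `CN(C)c1ccc(/C=C/C(=O)/C(CNc2ccccc2)=C(O)/C=C/c2ccc(N(C)C)cc2)cc1` bears an anilinomethyl group on it. In a physicochemical assay (on this read-out higher numbers stand for weaker inhibition and lower numbers for stronger inhibition), compound 1 gives 74.6 ug/mL, and in the same assay compound 2 gives 52.1 ug/mL. These two numbers lie within the usual scatter of one another, so nothing separates compound 2 from compound 1 on this read-out; it simply stands alongside it.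

Compound 3 `CN(C)c1ccc(/C=C/C(=O)/C(CNc2ccc(F)cc2)=C(O)/C=C/c2ccc(N(C)C)cc2)cc1` is the compound for which no number exists yet. It differs from compound 2 in a single place: fluoro in place of hydrogen on an aromatic carbon. The anilinomethyl group thus becomes a ((4-fluorophenyl)amino)methyl group, and everything else is kept.

For the measured compounds named here, no step of this kind has been measured, and the one comparison available, compound 1 against compound 2, stayed within the scatter. The expectation is therefore a step of a 1.0-fold lower number from compound 2 to compound 3 (0.02 log units; within the scatter) in this assay that does not reach beyond the scatter in either direction. Compound 3 is estimated to give about 50 ug/mL, with a plausible range from 30 ug/mL to 85 ug/mL.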

Compound 3, half-maximal inhibitory concentration: 46.9 ug/mL
Beside the measured number, compound 3's estimate is 1.1-fold (0.03 log units) above it; low and high end bracket the measured number.
By their numbers in this assay, from the lowest: compounds 3, 2 and 1 (each within the scatter of the next).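

For the compounds shown here, replacing hydrogen with fluoro on an aromatic carbon, para to a large group, gives a 1.1-fold lower number from compound 2 to compound 3 (0.05 log units; within the scatter) in this assay and is the first step that changes a single atom on the aniline ring. On this read-out, compound 3 cannot be told apart from compound 2, so this ring position can carry a fluorine atom with no measurable consequence here, and a single step of this size gives no sign that the position matters either way. No measurement at hand bears on why these two numbers stand so close together.

Fluoro is only one small atom, so it remains open whether a bulkier or chemically different group on the same carbon, such as methoxy, trifluoromethyl or a carboxylic acid, would move the number beyond the scatter. As far as these compounds go, it is equally open whether the anilinomethyl group matters as a whole, a question that replacing its phenyl ring with a simple alkyl chain such as butyl could begin to answer.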